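Swapping in (4-chlorophenyl)amino on the shared core

The source may hold more compounds than are shown below. What is called first, only, known or untested is meant among the compounds shown, and "the series" means these compounds.

compound 1 `COc1cc(C(=O)c2sc3ccccc3c2-c2ccc(Cl)cc2)cc(OC)c1OC` gives 4200 nM
compound 2 `COc1ccc(OC)c(-c2c(C(=O)c3cc(OC)c(OC)c(OC)c3)sc3ccccc23)c1` gives > 10000 nM (a limit)

Both results come from a functional assay on K562 cells (Homo sapiens) for antiproliferative activity, read by MTT assay, with a stated time of 72 h; on this read-out higher numbers stand for weaker inhibition and lower numbers for stronger inhibition. Compound 2 stands at a limit, > 10000 nM, so no exact number is known for it. The data hold (the limit of > 10000 nM in this assay, at which 1 of the 2 values shown sits). Going by the values given here, only one measured step bears on the change, an at least 2.3-fold higher number from compound 1 to compound 2 (0.37 log units; beyond the scatter), which lies beyond the scatter and arises with 2,5-dimethoxyphenyl in place of 4-chlorophenyl. Compound 3 `COc1cc(C(=O)c2sc3ccccc3c2Nc2ccc(Cl)cc2)cc(OC)c1OC` alters the same carbon: (4-chlorophenyl)amino in place of 2,5-dimethoxyphenyl on an aromatic carbon. The entering (4-chlorophenyl)amino carries the ring of compound 1 , which gives 4200 nM, so a modest move toward stronger inhibition seems likely. Among the compounds with values here, no measured step covers the amino link, which keeps the expectation loose. The expected change is an at least 3.3-fold lower number from compound 2 to compound 3 (0.52 log units; beyond the scatter). For compound 3 the estimate is 3000 nM, with an expected range from 600 nM to 10000 nM.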

Compound 3, half-maximal inhibitory concentration: 1100 nM
Estimate against measurement, compound 3: 2.7-fold (0.44 log units) above; the range from low to high includes it.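

In this assay, this position on the five-membered ring responds to the link as well as to the ring it carries: keeping the 4-chlorophenyl ring but attaching it through an amino link gives a 3.8-fold lower number from compound 1 to compound 3 (0.58 log units; beyond the scatter). The larger change, an at least 9.0-fold lower number from compound 2 to compound 3 (0.95 log units; beyond the scatter), alters the ring and the link together, so it cannot be divided between those two changes. Compound 2 stands at a limit, so that step gives only a lower bound on the change: the limit of > 10000 nM in this assay, at which 1 of the 3 values shown sits.

From the compounds shown here alone, it remains open whether the amino link needs its hydrogen, which a methylamino link would test, or whether an ether oxygen or a methylene link would serve as well. Also open, going by these compounds, is how the 2,5-dimethoxyphenyl ring would behave when attached through the same amino link.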